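The compounds below may be only part of what the source reports. "The series", "measured", "known", "first", "only" and "open" are said of these compounds alone.

Measured set in an assay on CHO cells for inhibition of Glucagon receptor (Homo sapiens), tested at 20 uM; on this read-out higher numbers stand for more inhibition at the one concentration tested (going by the name of the read-out) and lower numbers for less inhibition:
compound 1, `CCCCCc1c(C(C)C)nc(C(C)C)c(CO)c1-c1ccc(OC)cc1`, 37%
compound 2, `CCCCCc1c(C(C)C)nc(C(C)C)c(CO)c1-c1ccc(O)cc1`, 24%
compound 3, `CCCCCc1c(C(C)C)nc(C(C)C)c(CO)c1-c1ccccc1CO`, 44%

Compound 3 gives the highest of the three numbers. One of its two steps is a number 7 percentage points higher from compound 1 to compound 3 (within the scatter) and lies within the scatter, so no order between those two compounds is claimed; the other is a number 20 percentage points higher from compound 2 to compound 3 (beyond the scatter) and lies beyond it.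

Compound 4 is `CCCCCc1c(C(C)C)nc(C(C)C)c(CO)c1-c1ccccc1C`. From compound 3 the change is hydrogen in place of hydroxy on a saturated chain carbon bound to an aromatic carbon. For the measured compounds named here, no measured step removes a hydroxy from a chain carbon. Going by the values given here, the only step that touches an oxygen is a number 13 percentage points lower from compound 1 to compound 2 (beyond the scatter), where hydrogen replaced methyl on an aromatic oxygen, and the two aryl exchanges a number 7 percentage points higher from compound 1 to compound 3 (within the scatter) and a number 20 percentage points higher from compound 2 to compound 3 (beyond the scatter) swap the whole aryl group rather than one group on it. The measured steps therefore do not constrain this change, and a small step in either direction is plausible, with nothing beyond the scatter as the working assumption. Compound 4 is estimated at 38%, between 20% and 55%, which means an expected step of a number 6 percentage points lower from compound 3 to compound 4 (within the scatter).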

Compound 4, a percentage reported as inhibition, at one concentration (the size of the read-out at that concentration, not a potency): 33%
Beside the measured number, compound 4's estimate is 5 percentage points above it; measured number inside the range.
By their numbers in this assay, from the lowest: compounds 2, 4, 1 and 3 (each within the scatter of the next, the first and the last beyond it).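

Taking the hydroxy off the saturated chain carbon bound to an aromatic carbon gives a number 11 percentage points lower from compound 3 to compound 4 (beyond the scatter) in this assay, so this single hydroxy accounts for a readable part of the number for compound 3. Without it, 2-methylphenyl is not separated from either para-free comparison: the aryl exchanges give a number 9 percentage points higher from compound 2 to compound 4 (within the scatter) and a number 4 percentage points lower from compound 1 to compound 4 (within the scatter), so 2-methylphenyl cannot be ordered against 4-hydroxyphenyl or 4-methoxyphenyl, whereas 2-(hydroxymethyl)phenyl does stand clear of 4-hydroxyphenyl. No supporting data bear on the reason for the hydroxy step.

Open, going by these compounds, is whether the step is specific to hydroxy or would also hold for an aminomethyl, a methoxymethyl or a carboxylic acid on the same carbon. On these data alone, all of these numbers come from one concentration, so the ranking of potency remains open.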